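This account rests on a few compounds, and the source may have more. Where it says the series, first, only, none or still open, it means among the compounds named here.

Working notes on the series. Compound 1, `OC[C@H]1O[C@@H](n2cnc3c(NCc4ccc(Br)cc4)ncnc32)[C@H](O)[C@@H]1O`, is the reference point. In a functional assay on G-361 cells (Homo sapiens) for antiproliferative activity, with a stated time of 72 h (on this read-out lower numbers stand for stronger inhibition and higher numbers for weaker inhibition), compound 1 gives only a limit of the assay, > 166000 nM, so no number is known for it. Compound 2, `OC[C@H]1O[C@@H](n2cnc3c(NCc4ccc(F)cc4Cl)ncnc32)[C@H](O)[C@@H]1O`, likewise returns a limit in this assay, > 166000 nM. Compound 3, `OC[C@H]1O[C@@H](n2cnc3c(NCc4ccccc4OC(F)F)ncnc32)[C@H](O)[C@@H]1O`, also returns a limit, > 166000 nM. All three measured values therefore sit at the same place, (the limit of > 166000 nM in this assay, at which 3 of the 3 values shown sit), and the three steps among them, a step that the two limits leave unreadable from compound 1 to compound 2, a step that the two limits leave unreadable from compound 1 to compound 3 and a step that the two limits leave unreadable from compound 2 to compound 3, cannot be read in size or direction.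

The step under consideration leads to compound 4, `OC[C@H]1O[C@@H](n2cnc3c(NCc4ccc(C(F)(F)F)cc4)ncnc32)[C@H](O)[C@@H]1O`, which differs from compound 1 by trifluoromethyl in place of bromo on an aromatic carbon. For the measured compounds named here, no measured step bears on this exchange, and the measured steps that do exist are unreadable because the limit of > 166000 nM in this assay, at which 3 of the 3 values shown sit, applies to every value in hand. The only indication is that three different aryl substitution patterns on the same core all failed to reach a measurable number in this assay.

On that basis compound 4 is expected to remain beyond the limit as well, so the step that the limit leaves unreadable from compound 1 to compound 4 is estimated as none beyond the scatter. The estimate for compound 4 in this assay is 250000 nM, within a range of 120000 nM to 600000 nM, with a high chance that only a limit is reported.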

Compound 4, half-maximal inhibitory concentration: > 166000 nM
Compound 4 gave a limit, no number; the forecaster's own chance of this, stated with the estimate: 85%; the middle value is on the limit's open side.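

Compound 4 also returns only a limit in this assay, > 166000 nM, so its steps to compound 1, compound 2 and compound 3 cannot be read in size or direction: the limit of > 166000 nM in this assay, at which 4 of the 4 values shown sit.

The compounds shown leave open whether any aryl group on the shared core gives a measurable number in this assay.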